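Extending the bromoalkoxy chain into a carboxylic acid

The source may hold more compounds than are shown below. What is called first, only, known or untested is meant among the compounds shown, and "the series" means these compounds.

Three isoflavone-type compounds sharing one core have been tested in an assay on isolated protein (Cricetulus griseus) for inhibition of Monoamine oxidase (Homo sapiens); a lower number here means a stronger inhibitor, a higher number a weaker inhibitor. Compound 1 `O=c1c(-c2ccc(O)cc2)coc2cc(OCCCCCCBr)ccc12` gives 2000 nM, compound 2 `O=c1c(-c2ccc(O)cc2)coc2cc(OCCCCBr)ccc12` gives 4000 nM, and compound 3 `O=c1c(-c2ccc(O)cc2)coc2cc(OCCCBr)ccc12` gives 150 nM. Compound 2 thus carries the highest number of the three; its nearest neighbour is compound 1, with a 2.0-fold higher number from compound 1 to compound 2 (0.30 log units; within the scatter), while compound 3 sits far away, with a 27-fold lower number from compound 2 to compound 3 (1.43 log units; beyond the scatter) and, against compound 1, a 13-fold lower number from compound 1 to compound 3 (1.12 log units; beyond the scatter).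

Compound 4 `O=C(O)CCCCCCOc1ccc2c(=O)c(-c3ccc(O)cc3)coc2c1` arises from compound 2 by 2-carboxyethyl in place of bromo on a saturated chain carbon, four bonds along the chain from an oxygen on an aromatic ring. Going by the values given here, no measured step swaps a bromine for a carboxyl-bearing chain, so nothing here speaks directly to that exchange. The measured steps only concern chain length: shortening the chain from compound 2 to compound 3 lowered the number greatly, whereas lengthening it from compound 2 to compound 1 stayed within the scatter. On these data alone, compound 4 lengthens the chain further still, so on the chain-length evidence alone no large movement away from compound 2 is expected, and the effect of the terminal carboxylic acid remains unknown. Compound 4 is therefore expected to give 5000 nM in this assay, within a range of 1000 nM to 25000 nM, corresponding to an estimated step of a 1.3-fold higher number from compound 2 to compound 4 (0.10 log units; within the scatter).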

Compound 4, half-maximal inhibitory concentration: 2100 nM
Estimate against measurement, compound 4: 2.4-fold (0.38 log units) above; the range from low to high includes it.
By their numbers in this assay, from the lowest: compound 3; then compounds 1, 4 and 2 (each within the scatter of the next).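

Replacing the terminal bromine with a chain ending in a carboxylic acid leaves the number in this assay within the scatter of compound 2 (a 1.9-fold lower number from compound 2 to compound 4 (0.28 log units; within the scatter)) and of compound 1 (a 1.1-fold higher number from compound 1 to compound 4 (0.02 log units; within the scatter)). The earlier compounds shown here held only bromine at the chain end, so they could not show that this position also tolerates a long chain with a carboxylic acid, which brings in a hydrogen-bond donor and acceptor that bromine lacks, without a step beyond the scatter. Going by these compounds alone, compound 3, with its 3-bromopropyl chain, remains the strongest inhibitor of the four, and the new compound stands well apart from it (a 14-fold higher number from compound 3 to compound 4 (1.15 log units; beyond the scatter)), so the large gain is still seen only with that short bromo chain.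

That last step changes both chain length and end group at once, so the compounds shown cannot separate the two, and a carboxylic acid on a chain as short as that of compound 3, or an amine at the end of a long chain, would be needed to tell them apart. No supporting data are available to explain why these numbers fall as they do.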